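This account rests on a few compounds, and the source may have more. Where it says the series, first, only, none or still open, it means among the compounds named here.

Compound 3 `Oc1ccccc1-c1ccc2c(-c3cncnc3)cccc2c1` sits at the limit of an assay for binding affinity to 17-beta-hydroxysteroid dehydrogenase type 2 (Homo sapiens), read by scintillation counting, with a stated time of 10 min, tested at 1 uM; a lower number here means less inhibition, a higher number more inhibition at the concentration tested (going by the name of the read-out): it gives < 10%, which is a limit of the assay and not a number (the limit of < 10% in this assay, at which 1 of the 3 values shown sits). Compound 4 `Oc1cccc(-c2ccc3c(-c4cncnc4)cccc3c2)c1` differs from it in one place, (3-hydroxyphenyl in place of 2-hydroxyphenyl on an aromatic carbon). For the measured compounds named here, no measured step covers this change. Going by the values given here, the one step recorded concerns another position: compound 1 `Oc1cccc(-c2ccc3c(-c4cncnc4)c(O)ccc3c2)c1` gives 85% in this assay, compound 2 `Cn1cc(-c2c(O)ccc3cc(-c4cccc(O)c4)ccc23)cn1` gives 24%, and the step is a number 61 percentage points lower from compound 1 to compound 2 (beyond the scatter). Both compound 3 and compound 4 keep the pyrimidin-5-yl group that compound 1 carries. Among the compounds with values here, compound 1 also carries 3-hydroxyphenyl, together with a further hydroxyl that compound 4 lacks, and no step between compound 1 and compound 4 has been measured. With compound 3 at the limit, only compound 1 offers a number to lean on. The step from compound 3 to compound 4 is estimated at a number at least 20 percentage points higher from compound 3 to compound 4 (beyond the scatter), a rise beyond the scatter. Compound 4 is expected to give 30% in this assay, within 5% to 65%.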

Compound 4, a percentage reported as inhibition, at one concentration (the size of the read-out at that concentration, not a potency): < 10%
Compound 4: no number, only a limit (the forecaster's own chance of this, stated with the estimate: 25%); middle value at least 20 percentage points from the limit.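

With 3-hydroxyphenyl in place of 2-hydroxyphenyl, compound 4 stays at the limit in this assay, as compound 3 does, so the step between them cannot be read: the limit of < 10% in this assay, at which 2 of the 4 values shown sit.
The readable step lies at another place, hydrogen in place of hydroxy on an aromatic carbon: a number at least 75 percentage points lower from compound 1 to compound 4 (beyond the scatter).
For the compounds shown here, compound 1 and compound 4 both carry 3-hydroxyphenyl and pyrimidin-5-yl, so 3-hydroxyphenyl does not by itself give a measurable read-out here, and only compound 1 keeps the further hydroxyl, a contribution the earlier compounds could not separate.

Going by these compounds, whether another group, such as an amine or a carboxylic acid, could stand in place of that hydroxyl stays open. On these data alone, how 2-hydroxyphenyl compares with 3-hydroxyphenyl when that hydroxyl is present also stays open.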